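The compounds below may be only part of what the source reports. "The series", "measured", "known", "first", "only" and "open" are said of these compounds alone.

Measured so far:
Compound 1 `CC(C)(C)c1cc(C(=O)Nc2ccccn2)n(Cc2ccccc2)n1`: 6.3 ug/mL
Compound 2 `NCc1csc(NC(=O)c2cn(Cc3ccccc3)nn2)n1`: 25 ug/mL

In a physicochemical assay for solubility, read by nephelometry, measured as kinetic solubility, at pH 6.5 (on this read-out higher numbers stand for higher solubility and lower numbers for lower solubility), compound 1 gives 6.3 ug/mL, the lowest of the two numbers shown. Compound 2 gives 25 ug/mL, a higher number, and the gap between the two lies beyond the usual scatter. The two compounds differ in several places at once, so their values show only that the one sits higher than the other.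

Compound 3 `CC(C)(C)c1cc(C(=O)Nc2nc(CO)cs2)n(Cc2ccccc2)n1` has not yet been measured. It differs from compound 1 in a single place: 4-(hydroxymethyl)-1,3-thiazol-2-yl in place of pyridin-2-yl on an amide-type nitrogen. For the measured compounds named here, no pair of measured compounds shows this change on its own, so there is no measured step to lean on. The step from compound 1 to compound 3 is expected to be a modest rise, a 2.2-fold higher number from compound 1 to compound 3 (0.35 log units; beyond the scatter), a little beyond the scatter but not large. Compound 3 is estimated to give 14 ug/mL in this assay, within a range from 5 ug/mL to 40 ug/mL.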

Compound 3, solubility: 3.1 ug/mL
Compound 3: middle estimate off by 4.5-fold (0.65 log units), on the high side; the measured number lies below the stated range.
By their numbers in this assay, from the lowest: compound 3; then compound 1; then compound 2.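

In this assay, placing 4-(hydroxymethyl)-1,3-thiazol-2-yl in place of pyridin-2-yl on the amide-type nitrogen gives a 2.0-fold lower number from compound 1 to compound 3 (0.31 log units; beyond the scatter), the first change seen on its own at this position. The read-out therefore responds to what sits on this nitrogen, and here the number falls even though the entering group has 1 hydrogen-bond donor and 3 hydrogen-bond acceptors, against 0 and 1 for the group that leaves. No measurement shown explains the fall.

The step swaps the ring and adds the hydroxymethyl at once, so it leaves open which of the two goes with the lower number. A plain 1,3-thiazol-2-yl on this nitrogen would separate them, and a carboxylic acid in place of the hydroxymethyl would test another kind of group on the same ring.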